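The source may report more compounds than this note shows. Statements on the series, on what has been measured and on what is new or still open speak of the compounds shown alone.

Working notes on the series. The shared core is seen in compound 1 `O=C1N=C(N2N=C(c3ccccc3)CC2c2ccccc2O)S/C1=C1/C(=O)Nc2ccccc21`, which in a functional assay on cells (Cancer cell lines, Homo sapiens) for cytotoxicity, read by sulforhodamine B assay, with a stated time of 48 h (on this read-out higher numbers stand for weaker inhibition of growth and lower numbers for stronger inhibition of growth), gives 5370 nM. Compound 2 `O=C1N=C(N2N=C(c3ccccc3)CC2c2ccc(Cl)cc2)S/C1=C1/C(=O)Nc2ccccc21` carries 4-chlorophenyl on the saturated ring carbon and in this assay gives 500 nM; the step of an 11-fold lower number from compound 1 to compound 2 (1.03 log units; beyond the scatter) is the one large move in the set. Compound 3 `Cc1ccc2c(c1)/C(=C1\SC(N3N=C(c4ccccc4)CC3c3ccc(Cl)cc3)=NC1=O)C(=O)N2` adds a methyl on an aromatic carbon and in this assay gives 320 nM; the step of a 1.6-fold lower number from compound 2 to compound 3 (0.19 log units; within the scatter) stays inside the scatter. Compound 2 thus stands second highest of the three numbers, within the scatter of compound 3 and well apart from compound 1.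

Compound 4 `O=C1N=C(N2N=C(c3ccc4ccccc4c3)CC2c2ccc(Cl)cc2)S/C1=C1/C(=O)Nc2ccccc21` is not yet measured. It differs from compound 2 by naphthalen-2-yl in place of phenyl on a carbon with a double bond to nitrogen. Neither measured step touches this carbon: the step of an 11-fold lower number from compound 1 to compound 2 (1.03 log units; beyond the scatter) changes the group on the saturated ring carbon, and the step of a 1.6-fold lower number from compound 2 to compound 3 (0.19 log units; within the scatter) adds a methyl on an aromatic carbon without leaving the scatter. Within the data shown here, the nearest precedent is the small aromatic addition in compound 3, so no move beyond the scatter is expected in this assay, with at most a slight lean toward a lower number. Compound 4 is expected to give 400 nM in this assay, within 130 nM to 1500 nM, an expected step of a 1.3-fold lower number from compound 2 to compound 4 (0.10 log units; within the scatter).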

Compound 4, concentration for total growth inhibition: 27300 nM
The estimate for compound 4 lay 68-fold (1.83 log units) below the measured number; the measured number lies above the stated range.
By their numbers in this assay, from the lowest: compounds 3 and 2 (each within the scatter of the next); then compound 1; then compound 4.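

Among these compounds, the carbon with a double bond to nitrogen, which no earlier step touched, proves highly sensitive in this assay: naphthalen-2-yl in place of phenyl gives a 55-fold higher number from compound 2 to compound 4 (1.74 log units; beyond the scatter), a larger move than an 11-fold lower number from compound 1 to compound 2 (1.03 log units; beyond the scatter) at the saturated ring carbon. A small aromatic addition elsewhere therefore says little about this position, and growth inhibition here does not tolerate every carbon-only aromatic group. The change adds a second six-membered aromatic ring of carbon only, while hydrogen-bond donors, hydrogen-bond acceptors and net charge stay the same in the leaving and entering groups, and no measurement at hand accounts for the loss.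

The compounds shown leave open whether the loss belongs to the second ring as such or to the way it is attached, since only phenyl and naphthalen-2-yl appear at this carbon, and a naphthalen-1-yl, a 4-methoxyphenyl or a saturated cyclohexyl group would help to separate these. Also open, as far as these compounds go, is whether naphthalen-2-yl has the same effect on the methyl-bearing core of compound 3 or alongside the 2-hydroxyphenyl group of compound 1.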